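Amidine in Place of Hydroxycarbamoyl: Compound 4 Expected

The compounds below may be only part of what the source reports. "The series", "measured", "known", "first", "only" and "open" are said of these compounds alone.

Compound 1 `CCOc1ccc(Br)cc1-c1cc(Nc2ccc(C#N)cc2)nc(N)n1` gives 17 nM in an assay on Sf9 cells for inhibition of 1-acyl-sn-glycerol-3-phosphate acyltransferase beta (Homo sapiens); a lower number here means a stronger inhibitor, a higher number a weaker inhibitor.
Compound 2 `CCOc1ccc(Br)cc1-c1cc(Nc2cccc(C#N)c2)nc(N)n1` gives 720 nM in this assay.
Compound 3 `CCOc1ccc(Br)cc1-c1cc(Nc2ccc(C(=O)NO)cc2)nc(N)n1` gives 88 nM in this assay.

Compound 3 stands second highest of the three numbers. Its nearest neighbour is compound 1, separated from it by a 5.2-fold higher number from compound 1 to compound 3 (0.71 log units; beyond the scatter), while compound 2 lies furthest from it.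

Compound 4 `CCOc1ccc(Br)cc1-c1cc(Nc2ccc(C(=N)N)cc2)nc(N)n1` differs from compound 3 in one place: a group of 3 heavy atoms (1 carbon, 2 nitrogen; no ring) in place of a group of 4 heavy atoms (1 carbon, 1 nitrogen, 2 oxygen; no ring), on an aromatic carbon. Of the measured steps, only one bears on this position: a 5.2-fold higher number from compound 1 to compound 3 (0.71 log units; beyond the scatter), in which hydroxycarbamoyl entered in place of cyano on the same aromatic carbon and raised the number by a modest amount. The other step, a 42-fold higher number from compound 1 to compound 2 (1.63 log units; beyond the scatter), concerns 3-cyanophenyl in place of 4-cyanophenyl on the nitrogen and does not touch the group exchanged here. For the measured compounds named here, no measured compound carries the entering group, so the direction of the change is uncertain; the one step at this position shows that exchanges of this group move the number modestly. Compound 4 is therefore expected to land near compound 3. Compound 4 is expected to show a step of a 1.4-fold higher number from compound 3 to compound 4 (0.13 log units; within the scatter), with an estimated value of 120 nM and a range from 30 nM to 500 nM.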

Compound 4, half-maximal inhibitory concentration: > 5000 nM
Compound 4 ended at the assay's limit; the forecaster's own chance of this, stated with the estimate: 5%; at least 41-fold (1.61 log units) between middle value and limit.
By their numbers in this assay, from the lowest: compound 1; then compound 3; then compound 2. At a limit, above all of these: compound 4.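

In this assay compound 4 gives a limit of the assay and not a number: the limit of > 5000 nM in this assay, at which 1 of the 4 values shown sits. The earlier compounds shown here showed this aromatic carbon accepting both the nitrile and hydroxycarbamoyl with only a modest change, yet the exchange of hydroxycarbamoyl for the group of 3 heavy atoms produces an at least 56-fold higher number from compound 3 to compound 4 (1.75 log units; beyond the scatter), and the comparison with the nitrile gives an at least 290-fold higher number from compound 1 to compound 4 (2.46 log units; beyond the scatter), so this position proves far less forgiving than that single earlier step suggested. Even against the 3-cyanophenyl compound, the highest number measured before, the result is an at least 6.9-fold higher number from compound 2 to compound 4 (0.84 log units; beyond the scatter), which means that this one exchange on the aromatic carbon costs more than moving the nitrile did.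

The limit leaves the true size of all three steps unknown, and with only three groups at this carbon, the compounds shown cannot tell which feature of the entering group goes with the loss. A carboxylic acid, a primary amide or an aminomethyl group on the same aromatic carbon would show whether the steep rise belongs to this group alone or extends to other groups there.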